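Piperidine to methylpiperazine on the propoxy chain

The source may hold more compounds than are shown below. What is called first, only, known or untested is meant among the compounds shown, and "the series" means these compounds.

Measured compounds:
compound 1 `COc1cc2c(Oc3ccc(NC(=O)c4cn(-c5c(C)cccc5C)nn4)cc3F)ccnc2cc1OCCCN1CCCCC1`, a functional assay on A549 cells (Homo sapiens) for cytotoxicity, read by MTT assay, with a stated time of 72 h; on this read-out higher numbers stand for weaker inhibition and lower numbers for stronger inhibition: "not determined" (no result reported)
compound 2 `COc1cc2c(Oc3ccc(NC(=O)c4cn(-c5c(Cl)cccc5Cl)nn4)cc3F)ccnc2cc1OCCCN1CCCCC1`, this assay: 150 nM

Compound 1 has no single number on this read-out; its result in this assay is given only as "not determined" (no result reported). The one figure in hand comes from compound 2, which in this assay gives 150 nM, so the series as a whole sits in the sub-micromolar region on the numbers shown, without any direct figure for compound 1 itself.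

Compound 3 `COc1cc2c(Oc3ccc(NC(=O)c4cn(-c5c(C)cccc5C)nn4)cc3F)ccnc2cc1OCCCN1CCN(C)CC1` is the next compound to be measured in this assay. It differs from compound 1 in one place: 4-methylpiperazin-1-yl in place of piperidin-1-yl on a saturated chain carbon, three bonds along the chain from an oxygen on an aromatic ring. For the measured compounds named here, no step between measured compounds is available for this change, so its size is unknown. The expectation is a small step, most likely none beyond the usual scatter of this assay, in either direction.

On that basis compound 3 is estimated to give 200 nM in this assay, expected to fall within the range 50 nM to 800 nM.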

Compound 3, half-maximal inhibitory concentration: 2180 nM
Beside the measured number, compound 3's estimate is 11-fold (1.04 log units) below it; measured number outside the range, above it.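

For the compounds shown here, compound 1 has no single number in this assay, so no step from compound 1 to compound 3 can be read. The compounds shown leave open how far 4-methylpiperazin-1-yl in place of piperidin-1-yl shifts this read-out on the shared core. No evidence at hand bears on the value of compound 3.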